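Phenyl for Benzyl on the Triazole: Cytotoxicity Outlook

A few compounds are considered here, and "the series" means these few. Any claim that something is new, unique, unknown or untested is made for them only; others in the source may bear on it.

Compound 1 `O=C1O/C(=C\Cn2cc(Cc3ccccc3)nn2)C(OCc2ccccc2)=C1OCc1ccccc1` — 70000 nM
Compound 2 `O=C1NC(O)(CCn2cc(-c3ccccc3)nn2)C(OCc2ccccc2)=C1OCc1ccccc1` — > 100000 nM

Going by the values given here, in an ADME assay on HEK293 cells (Homo sapiens) for cytotoxicity, read by MTT assay, with a stated time of 24 h (a lower number here means a stronger inhibitor, a higher number a weaker inhibitor), compound 1 gives 70000 nM, the only plain number among the two measured compounds. Compound 2 reached only a limit of this assay, > 100000 nM, which is the limit of > 100000 nM in this assay, at which 1 of the 2 values shown sits. Compound 3 `O=C1O/C(=C\Cn2cc(-c3ccccc3)nn2)C(OCc2ccccc2)=C1OCc1ccccc1` differs from compound 1 by phenyl in place of benzyl on an aromatic carbon. Among the compounds with values here, no measured pair shows this change alone, so the expectation rests on compound 1 and on the nearness of the two structures. A step within the usual scatter, leaning toward weaker inhibition, is expected: a 1.3-fold higher number from compound 1 to compound 3 (0.11 log units; within the scatter). Compound 3 is estimated at 90000 nM, with a likely range from 30000 nM to 300000 nM.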

Compound 3, half-maximal inhibitory concentration: > 100000 nM
Compound 3: a limit, no number; the forecaster's own chance of this, stated with the estimate: 40%; at least 1.1-fold (0.04 log units) between middle value and limit.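

Putting phenyl in place of benzyl on this aromatic carbon gives, in this assay, an at least 1.4-fold higher number from compound 1 to compound 3 (0.15 log units; that floor lies within the scatter). Going by these compounds alone, this is the first reading of this change alone, and it shows only a floor, so the true size of the step stays unknown. The value of compound 3 is a limit of the assay, as is now the case for most compounds shown: the limit of > 100000 nM in this assay, at which 2 of the 3 values shown sit.

On these data alone, whether the step truly goes beyond the scatter remains open. Also open, as far as these compounds go, is how an amine or a carboxylic acid on the phenyl ring would read in this assay.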